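The source may report more compounds than this note shows. Statements on the series, on what has been measured and on what is new or still open speak of the compounds shown alone.

Measured so far in a functional assay on HEK293 cells for activation of melanin-concentrating hormone receptor 1 (Homo sapiens), read by inositol phosphate accumulation; on this read-out higher numbers stand for an effect only at larger amounts of compound and lower numbers for an effect already at smaller amounts:
compound 1 `CC(C)(C)c1cc(N)c2cc(NC(=O)/C=C/c3ccc(C(F)(F)F)cc3)ccc2n1`, 29 nM
compound 2 `Nc1cc(C2CCC2)nc2ccc(NC(=O)/C=C/c3ccc(C(F)(F)F)cc3)cc12`, 250 nM
compound 3 `CC(C)c1cc(N)c2cc(NC(=O)/C=C/c3ccc(C(F)(F)F)cc3)ccc2n1`, 160 nM

Compound 3 stands second highest of the three numbers: the step of a 1.6-fold lower number from compound 2 to compound 3 (0.19 log units; within the scatter) lies within the scatter, while a 5.5-fold higher number from compound 1 to compound 3 (0.74 log units; beyond the scatter) lies beyond it. Compound 4 `Nc1cc(-c2ccccc2)nc2ccc(NC(=O)/C=C/c3ccc(C(F)(F)F)cc3)cc12` differs from compound 3 in one place: phenyl in place of isopropyl on an aromatic carbon. For the measured compounds named here, the measured steps swap one saturated group for another at that aromatic carbon, and an 8.6-fold higher number from compound 1 to compound 2 (0.94 log units; beyond the scatter) together with a 5.5-fold higher number from compound 1 to compound 3 (0.74 log units; beyond the scatter) shows the group there matters, but none of them brings in an aromatic ring, so no step speaks directly to this change. In this assay compound 4 is therefore expected close to compound 3 with a wide range, at 200 nM, from 40 nM to 1000 nM, which means a 1.3-fold higher number from compound 3 to compound 4 (0.10 log units; within the scatter).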

Compound 4, half-maximal effective concentration: 6600 nM
Compound 4: the middle estimate sits 33-fold (1.52 log units) below what was measured; the measured number lies above the stated range.
By their numbers in this assay, from the lowest: compound 1; then compounds 3 and 2 (each within the scatter of the next); then compound 4.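

Compound 4 is the only one shown with an aromatic ring on this carbon, and in this assay phenyl gives a 41-fold higher number from compound 3 to compound 4 (1.62 log units; beyond the scatter) and a 26-fold higher number from compound 2 to compound 4 (1.42 log units; beyond the scatter) and a 230-fold higher number from compound 1 to compound 4 (2.36 log units; beyond the scatter) as well. All three steps are large, so at this position going from a saturated group to phenyl weighs more than any swap among the saturated groups shown. No measurement at hand explains this loss.

On these data alone, whether every aromatic ring here would behave like phenyl stays open. A pyridine ring or a cyclohexyl group on this carbon would help separate the effect of ring size from that of an aromatic ring.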